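Replacing a Fluoro Group with a Fluorobenzyloxy Chain

The compounds below may be only part of what the source reports. "The series", "measured", "known", "first", "only" and "open" are said of these compounds alone.

Compound 1 `Fc1cccc(-c2cn([C@@H]3CN4CCC3CC4)nn2)c1` was tested in an assay on HEK293 cells for displacement of a labelled ligand from Neuronal acetylcholine receptor; alpha4/beta2 (Homo sapiens), read by scintillation counting, with a stated time of 120 min (a higher number here means a weaker inhibitor, a lower number a stronger inhibitor), where compound 1 gives 519 nM. This is the highest of the three numbers recorded so far, but only within the scatter, since compound 3 `Fc1ccc(-c2cn([C@@H]3CN4CCC3CC4)nn2)cc1` gives 515 nM in this assay and compound 2 `Fc1ccc(-c2cn(C3CN4CCC3CC4)nn2)cc1` gives 449 nM. Compounds 2 and 3 differ only in how one stereocentre is drawn, and the step of a 1.1-fold higher number from compound 2 to compound 3 (0.06 log units; within the scatter) stays within the scatter, which is unsurprising because of the fact that one of compounds 2 and 3 is drawn with a defined configuration and the other without, at the place where they differ.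

Compound 4 `Fc1ccc(COc2cccc(-c3cn([C@@H]4CN5CCC4CC5)nn3)c2)cc1` has not yet been measured. It differs from compound 1 by (4-fluorobenzyl)oxy in place of fluoro on an aromatic carbon, meta to a large group. Among the measured compounds shown here, no measured step covers a change of this kind; the single measured step concerns only a stereo drawing and offers no guide to the size or direction of the effect. The expectation for compound 4 is therefore an unchanged number with wide uncertainty, a step of a 1.3-fold higher number from compound 1 to compound 4 (0.13 log units; within the scatter), giving an estimated 700 nM with a range from 150 nM to 4000 nM.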

Compound 4, inhibition constant: 537 nM
Compound 4: middle estimate off by 1.3-fold (0.12 log units), on the high side, within the range that was stated.
By their numbers in this assay, from the lowest: compounds 2, 3, 1 and 4 (each within the scatter of the next).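

Putting (4-fluorobenzyl)oxy in place of fluoro on an aromatic carbon, meta to a large group, gives a 1.0-fold higher number from compound 1 to compound 4 (0.01 log units; within the scatter) in this assay. The earlier compounds shown here carried only fluoro on this aromatic ring, whereas compound 4 shows that this position can take a group of 9 heavy atoms, with a further six-membered aromatic ring of carbon only and 1 hydrogen-bond acceptor, while its number stays within the scatter of that of compound 1. Nothing on record accounts for this result.

This single step cannot show whether the oxygen link, the benzyl ring or the fluorine on that ring has any bearing on the number. It also leaves open whether an amine, a carboxylic acid or a longer alkyl chain at this position would leave the number within the scatter too.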